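The source may hold more compounds than are shown below. What is called first, only, known or untested is meant among the compounds shown, and "the series" means these compounds.

In an ADME assay on HL-60 cells (Homo sapiens) for cytotoxicity, read by resazurin assay, with a stated time of 72 h (on this read-out lower numbers stand for an effect already at smaller amounts and higher numbers for an effect only at larger amounts of compound), compound 1 `O=C(c1ccccc1)c1ccc2nc(NCCO)[nH]c2c1` gives > 30000 nM, which is a limit of the assay and not a number. Compound 2 `O=C(c1ccccc1)c1ccc2nc(NCCC3CCCNC3)[nH]c2c1` gives > 30000 nM, which is also a limit. Compound 2 therefore has no exact position on the scale, and the evidence so far is the limit of > 30000 nM in this assay, at which 2 of the 2 values shown sit. Within the data shown here, the only measured step is a step that the two limits leave unreadable from compound 1 to compound 2, so it offers no size to carry forward.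

Compound 3 `NCCCCNC(=O)Nc1nc2ccc(C(=O)c3ccccc3)cc2[nH]1` brings a different change: (4-aminobutyl)carbamoyl in place of 2-(piperidin-3-yl)ethyl on a nitrogen on an aromatic ring. The ring leaves with the 2-(piperidin-3-yl)ethyl group, and the (4-aminobutyl)carbamoyl group that enters has none.

Among the measured compounds shown here, no measured step describes this exchange, so any forecast is cautious. For compound 3, no step beyond the usual scatter is expected in this assay, and no direction is favoured, because of the limit of > 30000 nM in this assay, at which 2 of the 2 values shown sit. The expected size of the change is a number no higher from compound 2 to compound 3 (the limit leaves the size open), and this is an estimate with little behind it. For compound 3 the estimated value is 30000 nM, with an expected range from 10000 nM to 60000 nM, and a reading that is again only a limit is the likeliest outcome.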

Compound 3, half-maximal effective concentration: > 30000 nM
Compound 3 was reported as a limit; the forecaster's own chance of this, stated with the estimate: 65%; the middle value sits exactly at the limit.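

Compound 3 also gives only a limit in this assay, so none of the steps among compound 1, compound 2 and compound 3 can be read, and none has a size: the limit of > 30000 nM in this assay, at which 3 of the 3 values shown sit.

The compounds shown leave open at what amount, if any, each of the three would affect these cells, and whether their side chains differ in this effect.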